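A few compounds are considered here, and "the series" means these few. Any claim that something is new, unique, unknown or untested is made for them only; others in the source may bear on it.

Going by the values given here, compound 2 `Nc1nc(-c2ccc(CO)cc2)nc2sc(-c3ccccc3)nc12` gives 82 nM in an assay on CHO cells for displacement of a labelled ligand from adenosine receptor A1 (Homo sapiens), read by scintillation counting, with a stated time of 3 h (on this read-out higher numbers stand for weaker inhibition and lower numbers for stronger inhibition), the higher of the two numbers measured so far; compound 1 `Nc1nc(-c2cccc(CO)c2)nc2sc(-c3ccccc3)nc12` gives 32 nM, and the step of a 2.6-fold higher number from compound 1 to compound 2 (0.41 log units; beyond the scatter) is the only step recorded. Compound 3 `COc1ccc(-c2nc(N)c3nc(-c4ccccc4)sc3n2)cc1` differs from compound 2 by methoxy in place of hydroxymethyl on an aromatic carbon. Among the compounds with values here, no measured pair exchanges hydroxymethyl for methoxy; the one known step concerns where hydroxymethyl sits rather than its replacement, so it bears only loosely on this change. Compound 3 is therefore expected near 60 nM, between 15 nM and 240 nM, meaning an estimated step of a 1.4-fold lower number from compound 2 to compound 3 (0.14 log units; within the scatter), within the scatter.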

Compound 3, inhibition constant: 225 nM
Compound 3: middle estimate off by 3.8-fold (0.57 log units), on the low side; low and high end bracket the measured number.
By their numbers in this assay, from the lowest: compound 1; then compound 2; then compound 3.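

In this assay, the exchange of hydroxymethyl for methoxy, para to a large group, is not neutral: it gives a 2.7-fold higher number from compound 2 to compound 3 (0.44 log units; beyond the scatter). The entering group has the same heavy-atom count but no hydrogen-bond donor, and the combined change of position and group gives a 7.0-fold higher number from compound 1 to compound 3 (0.85 log units; beyond the scatter). No evidence bears on why the number rises.

Open, on these data alone, is whether methoxy would follow the same trend at the position hydroxymethyl holds in compound 1. Also open, as far as these compounds go, is where an amine or a longer chain in this place would fall relative to compound 2 and compound 3.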